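Series notes: piperazine amide versus pentyl on the shared core

This account rests on a few compounds, and the source may have more. Where it says the series, first, only, none or still open, it means among the compounds named here.

Measured so far in a functional assay on cells (Lymphocyte, Homo sapiens); a higher number here means a weaker inhibitor, a lower number a stronger inhibitor:
compound 1, `Nc1nc(N2CCN(C(=O)COc3ccc(Cl)cc3)CC2)c2nc(-c3ccc(F)cc3)sc2n1`, gives 490 nM
compound 2, `CCCCCN1CCN(c2nc(N)nc3sc(-c4ccc(F)cc4)nc23)CC1`, gives > 10000 nM

Compound 2 stands at the weak end of what has been measured: its value is a limit of this assay, not a number, as noted in the limit of > 10000 nM in this assay, at which 1 of the 2 values shown sits. Within the data shown here, the only measured step is an at least 20-fold higher number from compound 1 to compound 2 (1.30 log units; beyond the scatter), a large loss when the amide is replaced by a plain chain.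

Compound 3, `Nc1nc(N2CCN(C(=O)COc3ccc(F)cc3)CC2)c2nc(-c3ccc(F)cc3)sc2n1`, takes the opposite direction from compound 2: ((4-fluorophenoxy)methyl)carbonyl in place of pentyl on an amine nitrogen in a ring. This restores the amide of compound 1, differing from it only in the halogen on the aryl ring. The step from compound 1 to compound 2 therefore bears directly, in reverse, on this change. A large drop in the number is expected, an at least 14-fold lower number from compound 2 to compound 3 (1.15 log units; beyond the scatter), landing near compound 1. For compound 3 the expected value in this assay is 700 nM, with a range from 250 nM to 2500 nM.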

Compound 3, half-maximal inhibitory concentration: 70 nM
For compound 3 the middle estimate is 10-fold (1.00 log units) above the measured one; measured number below the stated range.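

Among these compounds, the halogen on the aryl ring of the amide side chain counts in this assay, which the earlier compounds could not show: fluoro in place of chloro on an aromatic carbon gives a 7.0-fold lower number from compound 1 to compound 3 (0.85 log units; beyond the scatter), a modest step but one that keeps the amide and changes a single atom. Exchanging pentyl for ((4-fluorophenoxy)methyl)carbonyl on the amine nitrogen in the ring gives an at least 140-fold lower number from compound 2 to compound 3 (2.15 log units; beyond the scatter), so the large effect of this position now appears with a second halogen. Compound 2 remains a limit and not a number: the limit of > 10000 nM in this assay, at which 1 of the 3 values shown sits.

The compounds shown hold only fluoro and chloro on that aryl ring, leaving open how a bromo, a methoxy or an unsubstituted phenyl would read. Also open, from the compounds shown here alone, is whether the ether oxygen is needed, which a longer chain ending in a phenyl ring on the carbonyl would test.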